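Swapping Trifluoromethyl for Trifluoromethoxy on a Second Core

The source may report more compounds than this note shows. Statements on the series, on what has been measured and on what is new or still open speak of the compounds shown alone.

Compound 1, `CC(O)(CSc1cccc(C(F)(F)F)c1)C(=O)Nc1cccc(S(F)(F)(F)(F)F)c1`, gives 12700 nM in a functional assay on LNCaP cells (Homo sapiens) for antiproliferative activity, read by propidium iodide staining, with a stated time of 96 h; on this read-out lower numbers stand for stronger inhibition and higher numbers for weaker inhibition.
Compound 2, `CC(O)(CSc1cccc(OC(F)(F)F)c1)C(=O)Nc1cccc(S(F)(F)(F)(F)F)c1`, gives 10900 nM in this assay.
Compound 3, `CC(O)(COc1ccccc1C(F)(F)F)C(=O)Nc1cccc(S(F)(F)(F)(F)F)c1`, gives 26300 nM in this assay.

Compounds 1 and 2 share one core and differ in a single place: trifluoromethoxy in place of trifluoromethyl on an aromatic carbon. That change gave a 1.2-fold lower number from compound 1 to compound 2 (0.07 log units; within the scatter), so the two values cannot be told apart. Compound 3 has a different core; the difference between the two cores is not broken down here. Its number in this assay is the highest of the three, beyond the scatter from both compound 1 and compound 2.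

Compound 4, `CC(O)(COc1ccccc1OC(F)(F)F)C(=O)Nc1cccc(S(F)(F)(F)(F)F)c1`, is not yet measured. It differs from compound 3 in one place: trifluoromethoxy in place of trifluoromethyl on an aromatic carbon. The change is the same kind as that from compound 1 to compound 2, but the surroundings differ: there the group sat meta to a large group, here it sits ortho to a large group. Resting on the small step seen from compound 1 to compound 2, compound 4 is expected to show a 1.2-fold lower number from compound 3 to compound 4 (0.08 log units; within the scatter), a step within the scatter. The estimate for compound 4 is 22000 nM, between 9000 nM and 50000 nM.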

Compound 4, half-maximal inhibitory concentration: 16100 nM
For compound 4 the middle estimate is 1.4-fold (0.14 log units) above the measured one; low and high end bracket the measured number.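

On the second core, putting trifluoromethoxy in place of trifluoromethyl again made no clear difference in this assay: the swap gave a 1.6-fold lower number from compound 3 to compound 4 (0.21 log units; within the scatter) and so the two values cannot be told apart. Set side by side, the two steps also agree with each other, so as far as this read-out can tell the swap carries over from one core to the other: the same change on two cores in this assay, a 1.2-fold lower number (0.07 log units; within the scatter) from compound 1 to compound 2 and a 1.6-fold lower number (0.21 log units; within the scatter) from compound 3 to compound 4, 1.4-fold (0.15 log units) apart, within the scatter of two such steps. This agreement only means that two small steps match; it does not show that the swap has any real effect on either core, and two cores are too few to predict the result on a third.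

The compounds shown leave open whether a different group on the same aromatic carbon, such as a nitrile or an amine, would move the number beyond the scatter. Among the compounds shown here, they also leave open what the difference between the two cores does to the number, since no single step here isolates it.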